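Bromo to nitro on the benzylidene ring of compound 2

A few compounds are considered here, and "the series" means these few. Any claim that something is new, unique, unknown or untested is made for them only; others in the source may bear on it.

Compound 1, `O=C1/C(=C/c2ccccc2Br)CCc2ccccc21`, in a functional assay on L1210 cells (Mus musculus) for inhibition; a lower number here means a stronger inhibitor, a higher number a weaker inhibitor: 33400 nM
Compound 2, `O=C1/C(=C/c2ccccc2Br)Cc2ccccc21`, in this assay: 64200 nM

Compound 2 carries the higher of the two numbers, but its gap to compound 1 lies within the scatter, so the two are not separated here. Compound 3, `O=C1/C(=C/c2ccccc2[N+](=O)[O-])Cc2ccccc21`, differs from compound 2 by nitro in place of bromo on an aromatic carbon. Among the compounds with values here, no measured pair shows this change, so nothing indicates its direction. The step of a 1.3-fold lower number from compound 2 to compound 3 (0.11 log units; within the scatter) is expected to stay within the scatter. Compound 3 is estimated at 50000 nM, with a range from 15000 nM to 180000 nM in this assay.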

Compound 3, half-maximal inhibitory concentration: 7610 nM
Compound 3: the middle estimate sits 6.6-fold (0.82 log units) above what was measured; measured number below the stated range.
By their numbers in this assay, from the lowest: compound 3; then compounds 1 and 2 (each within the scatter of the next).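

In this assay, nitro in place of bromo on this aromatic carbon, ortho to a large group, gives an 8.4-fold lower number from compound 2 to compound 3 (0.93 log units; beyond the scatter), a step beyond the scatter. Within the data shown here, compound 1 and compound 2 both carry bromo, so only this step shows that the number responds to the group at this position. The finding rests on this single pair.

From the compounds shown here alone, how an amine or a methoxy group at this position would read, and whether nitro has a similar effect on the core of compound 1, remains open. Nothing available explains the size of the step.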